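The source may hold more compounds than are shown below. What is called first, only, known or untested is meant among the compounds shown, and "the series" means these compounds.

Measured compounds:
Compound 1, `CNC(=O)N1CCCc2ccc(NC(=O)c3cccc(-c4ccn(C)n4)c3)cc21`: 99.5%
Compound 2, `CNC(=O)N1CCCc2ccc(NC(=O)c3ccccc3-c3ccccc3)cc21`: 60.4%

In a functional assay on MV4-11 cells (Homo sapiens) for antiproliferative activity, with a stated time of 6 days, tested at 6.25 uM (on this read-out higher numbers stand for a stronger effect at the one concentration tested and lower numbers for a weaker effect), compound 1 gives 99.5%, the higher of the two numbers on record. Compound 2, which carries a different aryl group on the benzamide, gives 60.4% in this assay, a number far enough below compound 1 to lie beyond the usual scatter. Compound 1 thus stands at the top of what has been measured, close to complete inhibition at the single concentration tested.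

Compound 3, `CNC(=O)N1CCCc2ccc(NC(=O)c3cccc(-c4ccn(C(C)=O)n4)c3)cc21`, has not yet been measured in this assay. It differs from compound 1 in one place: acetyl in place of methyl on an aromatic nitrogen

Going by the values given here, no measured pair shows the effect of this change. Since compound 1 already sits near the ceiling of the read-out, there is little room for an increase; the step of a number 11.5 percentage points lower from compound 1 to compound 3 (beyond the scatter) is expected to be small and downward, possibly within the scatter. The estimate for compound 3 in this assay is 88%, with a range from 55% to 100%.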

Compound 3, a percentage reported as inhibition, at one concentration (the size of the read-out at that concentration, not a potency): 87.6%
Beside the measured number, compound 3's estimate is 0.4 percentage points above it, within the range that was stated.
By their numbers in this assay, from the lowest: compound 2; then compound 3; then compound 1.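

Going by these compounds alone, replacing methyl with acetyl on an aromatic nitrogen of the five-membered ring gives the first direct reading at this position: in this assay the change produces a number 11.9 percentage points lower from compound 1 to compound 3 (beyond the scatter), a modest loss that is nonetheless real. The position therefore accepts acetyl, with its 3 heavy atoms and 1 hydrogen-bond acceptor, in place of the single heavy atom of methyl, while compound 3 keeps most of the effect at the one concentration tested. Nothing available explains the size or direction of this step.

The compounds shown leave open how an ethyl group, or a longer chain ending in an amine, would read on this same nitrogen. They also leave open whether this modest step reflects a difference in potency, since the read-out comes from a single concentration.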